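An Isobutylamino Swap at the Limit of Tolerance

The source may report more compounds than this note shows. Statements on the series, on what has been measured and on what is new or still open speak of the compounds shown alone.

Compound 1 (`COCCOc1nc(N)nc2c1ncn2/C=C1/CC1(CO)CO`), compound 2 (`CCCCCCCCOc1nc(N)nc2c1ncn2/C=C1/CC1(CO)CO`) and compound 3 (`Nc1nc(NC2CC2)c2ncn(/C=C3/CC3(CO)CO)c2n1`) share a core and were all tested in an ADME assay on Akata cells (Homo sapiens) for cytotoxicity, with a stated time of 7 days (a higher number here means that more compound is tolerated, a lower number that less compound is tolerated), without a readable number. Compound 1 gives > 20000 nM as a limit. Compound 2 gives > 20000 nM as a limit. Compound 3 gives > 20000 nM as a limit too. Compound 3 thus stands with the others at the limit of > 20000 nM in this assay, at which 3 of the 3 values shown sit, without a number of its own. Compound 4 (`CC(C)CNc1nc(N)nc2c1ncn2/C=C1/CC1(CO)CO`) differs from compound 3 in one place (isobutyl in place of cyclopropyl on a nitrogen on an aromatic ring) as cyclopropylamino gives way to isobutylamino. Within the data shown here, two measured steps bear on this (a step that the two limits leave unreadable from compound 1 to compound 3 and a step that the two limits leave unreadable from compound 2 to compound 3) and neither has a readable size. No step beyond the scatter is therefore expected in this assay and another limit is likely. The expected change is a number no higher from compound 3 to compound 4 (the limit leaves the size open) by this estimate. For compound 4 the estimated value is 20000 nM with 10000 nM to 40000 nM as the expected range.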

Compound 4, half-maximal cytotoxic concentration: > 24000 nM
Compound 4 ended at the assay's limit (the forecaster's own chance of this, stated with the estimate: 85%); middle value at least 1.2-fold (0.07 log units) away from the limit.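

In this assay, among these compounds, compound 4 gives > 24000 nM, which is a limit, so no step to it from compound 1, compound 2 or compound 3 can be read. The compounds shown leave open at what concentration any of them becomes cytotoxic.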